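This account rests on a few compounds, and the source may have more. Where it says the series, first, only, none or still open, it means among the compounds named here.

All three compounds measured here share one large core and were tested in a functional assay on MCF7 cells (Homo sapiens) for antiproliferative activity, read by MTT assay, with a stated time of 72 h; a higher number here means a weaker inhibitor, a lower number a stronger inhibitor. Compound 1 `CC1=CCC2C(CC[C@@]2(C)O)C(C)(C)C1CC[C@@H]1[C@@]2(C)CC[C@@H](O)C(C)(C)O[C@@H]2CC[C@]1(C)O` gives 44500 nM. Compound 2 `CC1=CC[C@H]2[C@H](CC[C@]2(C)O)C(C)(C)[C@@H]1CC[C@H]1[C@]2(C)CC[C@H](OC(=O)c3ccncc3)C(C)(C)O[C@H]2CC[C@@]1(C)O` gives 25300 nM, the second highest of the three numbers, yet its gaps to compound 1 and to compound 3 both fall within the scatter of repeat measurements. Compound 3 `CC1=CC[C@H]2[C@@H]1CC=C(C)[C@@H](CC[C@H]1[C@]3(C)CC[C@H](OC(=O)c4ccccc4)C(C)(C)O[C@H]3CC[C@@]1(C)O)C2(C)C` gives 23100 nM. Compound 4 `CC1=CC[C@H]2[C@H](CC[C@]2(C)O)C(C)(C)[C@@H]1CC[C@H]1[C@]2(C)CC[C@H](OC(=O)c3ccc(Cl)c(Cl)c3)C(C)(C)O[C@H]2CC[C@@]1(C)O` has not yet been measured; it differs from compound 2 in a single place: 3,4-dichlorophenyl in place of pyridin-4-yl on a carbonyl carbon. Among the measured compounds shown here, no pair of measured compounds differs in only one place, so no measured step shows what such a swap does. Since all three numbers lie close together, the step is expected to be small, a 1.3-fold lower number from compound 2 to compound 4 (0.10 log units; within the scatter), and not clearly beyond the scatter. Compound 4 is therefore expected to give about 20000 nM, within 8000 nM to 50000 nM.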

Compound 4, half-maximal inhibitory concentration: 11900 nM
Estimate against measurement, compound 4: 1.7-fold (0.23 log units) above; the measured number falls inside the stated range.
By their numbers in this assay, from the lowest: compounds 4, 3, 2 and 1 (each within the scatter of the next, the first and the last beyond it).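

In this assay, among the compounds shown here, 3,4-dichlorophenyl in place of pyridin-4-yl on a carbonyl carbon gives a 2.1-fold lower number from compound 2 to compound 4 (0.33 log units; beyond the scatter), the first change in a single place that can be read here. It shows that the group on this carbonyl carbon can move the number, although only modestly. Nothing measured here gives a reason for the step.

As far as these compounds go, whether the two chlorines or the loss of the ring nitrogen carries the step stays open, as compound 3 holds a phenyl but differs elsewhere too. A phenyl with one chlorine, or with an amine, on this same carbonyl carbon would help separate the two.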